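Cytotoxicity notes on a nucleoside series, with an estimate for compound 4

The compounds below may be only part of what the source reports. "The series", "measured", "known", "first", "only" and "open" are said of these compounds alone.

Compound 1 `COc1nc(N)nc2c1c(-c1ccccc1)cn2[C@@H]1O[C@H](CO)[C@@H](O)[C@H]1O`: in an ADME assay on MRC5 cells (Homo sapiens), read by MTT assay, with a stated time of 72 h (on this read-out lower numbers stand for stronger inhibition and higher numbers for weaker inhibition), compound 1 gives > 100000 nM, a limit of the assay.
Compound 2 `Cc1nc(N)c2c(-c3cc4ccccc4o3)cn([C@@H]3O[C@H](CO)[C@@H](O)[C@H]3O)c2n1`: in this assay compound 2 gives 91800 nM.
Compound 3 `Nc1nc(N)c2c(-c3ccccc3)cn([C@@H]3O[C@H](CO)[C@@H](O)[C@H]3O)c2n1`: in this assay compound 3 gives > 100000 nM, a limit of the assay.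

Compound 3 stands at a limit, and so does one further value, namely (the limit of > 100000 nM in this assay, at which 2 of the 3 values shown sit). Among the measured compounds shown here, the only one-place step among the measured compounds is a step that the two limits leave unreadable from compound 1 to compound 3, which both limits leave unreadable, so no size can be taken from it.

Compound 4 `Cc1nc(N)c2c(-c3ccccc3)cn([C@@H]3O[C@H](CO)[C@@H](O)[C@H]3O)c2n1` differs from compound 3 in one place: methyl in place of amino on an aromatic carbon. For the measured compounds named here, no measured step covers this change. Going by the values given here, compound 2 also carries a methyl on its core, and in this assay compound 2 gives 91800 nM; no step between compound 2 and compound 4 is available, so only the two values themselves can be compared.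

With every value at or near the limit, the step of a number no higher from compound 3 to compound 4 (the limit leaves the size open) is expected to be none beyond the scatter. Compound 4 is therefore estimated at 100000 nM in this assay, with a range from 40000 nM to 300000 nM, and a limit rather than a number is the more likely outcome.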

Compound 4, half-maximal inhibitory concentration: > 100000 nM
Compound 4: a limit, no number (the forecaster's own chance of this, stated with the estimate: 60%); the middle value lies on the limit itself.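

In this assay, the position between two ring nitrogen atoms now carries either amino or methyl with the phenyl group kept, and compound 3 and compound 4 both stay at the limit of the assay: the limit of > 100000 nM in this assay, at which 3 of the 4 values shown sit. The steps between limits, old and new, cannot be read, so the amino-to-methyl change has no size. Phenyl in place of 1-benzofuran-2-yl on an aromatic carbon gives the only readable step, an at least 1.0-fold higher number from compound 2 to compound 4 (0.03 log units; that floor lies within the scatter), and as that is a floor, the true size of this change stays open.

From the compounds shown here alone, whether an ethyl group or a dimethylamino group at this position would bring a number under the limit remains open. Also open, going by these compounds, is whether a group such as 2-thienyl, in place of phenyl, would give a number with the methyl kept.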